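Swapping a Trifluoromethyl for a Nitro Group on the Aromatic Ring

The compounds below may be only part of what the source reports. "The series", "measured", "known", "first", "only" and "open" are said of these compounds alone.

Two measured compounds share one core and differ in a single group on an aromatic carbon of a six-membered carbon ring. Compound 1 `CC(C)(C)c1ccc(C(=O)NN2C(=O)NC3(CC3(C)C)C2=O)cc1` carries a tert-butyl group there, while compound 2 `CC1(C)CC12NC(=O)N(NC(=O)c1ccc(C(F)(F)F)cc1)C2=O` carries a trifluoromethyl group at the same place. In a functional assay on the whole organism (Hindlimb) for inhibition, with Mus musculus as the target, with a stated time of 0.5 h (on this read-out lower numbers stand for an effect already at smaller amounts and higher numbers for an effect only at larger amounts of compound), compound 1 gives 30 mg/kg, and in this assay compound 2 gives 30 mg/kg. For the measured compounds named here, the step of no change at the digits printed from compound 1 to compound 2 (within the scatter) shows that exchanging these two groups did not move the read-out beyond the usual scatter, so compound 2 stands level with compound 1 on the numbers so far.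

Compound 3 `CC1(C)CC12NC(=O)N(NC(=O)c1ccc([N+](=O)[O-])cc1)C2=O` is the next variation: nitro in place of trifluoromethyl on an aromatic carbon. Going by the values given here, the only measured step that bears on this change is the earlier exchange at the same aromatic carbon, no change at the digits printed from compound 1 to compound 2 (within the scatter), and that step stayed within the scatter. With no other evidence, no step beyond the scatter is expected, so the estimated step is no change at the digits printed from compound 2 to compound 3 (within the scatter). Compound 3 is therefore expected to come in at 30 mg/kg, with a range from 10 mg/kg to 100 mg/kg.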

Compound 3, minimum effective dose: 300 mg/kg
Estimate against measurement, compound 3: 10-fold (1.00 log units) below; the measured number lies above the stated range.
By their numbers in this assay, from the lowest: compounds 1 and 2 (each within the scatter of the next); then compound 3.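

On this assay the exchange for nitro gives a 10-fold higher number from compound 2 to compound 3 (1.00 log units; beyond the scatter) when nitro replaces trifluoromethyl and a 10-fold higher number from compound 1 to compound 3 (1.00 log units; beyond the scatter) when it replaces tert-butyl, so compound 3 needs a larger dose for an effect than either of the other two. The earlier pair alone could have suggested that this aromatic carbon, para to a large group, tolerates whatever is placed there, but compound 3 shows that the choice of group can matter a great deal, even though the shared core is unchanged. Nothing available explains why nitro stands apart from tert-butyl and trifluoromethyl, and the counted differences between the groups are descriptions of the structures, not a cause.

Three groups are too few to show whether nitro is an unusual case or one example of a wider set of groups that fare poorly here. A chlorine atom, a methoxy group, an amine or a carboxylic acid on the same aromatic carbon could show whether the dose stays level with compound 1 and compound 2 or moves toward compound 3.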